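A Third Methoxy Group on the Ring of Compound 2

A few compounds are considered here, and "the series" means these few. Any claim that something is new, unique, unknown or untested is made for them only; others in the source may bear on it.

Of the compounds shown here, two built on a shared core have been measured in a functional assay on UACC-257 cells (Homo sapiens) for antiproliferative activity, with a stated time of 48 h; a higher number here means a weaker inhibitor of growth, a lower number a stronger inhibitor of growth. Compound 1 `Cc1cc(O)c(C2=NN(c3ccc(S(N)(=O)=O)cc3)C(c3ccccc3O)C2)cc1Cl` gives 22100 nM. Compound 2 `COc1ccc(C2CC(c3cc(Cl)c(C)cc3O)=NN2c2ccc(S(N)(=O)=O)cc2)cc1OC` gives 19700 nM. The step of a 1.1-fold lower number from compound 1 to compound 2 (0.05 log units; within the scatter) shows that swapping the whole group on the saturated ring carbon hardly moved the number. Compound 2 therefore holds the lower of the two numbers, yet it lies within the scatter of compound 1, so neither can be called the stronger inhibitor of growth.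

Compound 3 `COc1ccc(C2CC(c3cc(Cl)c(C)cc3O)=NN2c2ccc(S(N)(=O)=O)cc2)c(OC)c1OC` differs from compound 2 in a single place: methoxy in place of hydrogen on an aromatic carbon. Among the compounds with values here, the only measured step that bears on this change is a 1.1-fold lower number from compound 1 to compound 2 (0.05 log units; within the scatter), which altered the same part of the molecule far more drastically and still stayed within the scatter. Nothing in the measured pair suggests that one further methoxy group would shift the result. The step expected from this change is a 1.0-fold lower number from compound 2 to compound 3 (0.02 log units; within the scatter), none beyond the scatter. Compound 3 is accordingly estimated at 19000 nM in this assay, with a range from 8000 nM to 45000 nM.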

Compound 3, concentration for total growth inhibition: 15200 nM
Beside the measured number, compound 3's estimate is 1.3-fold (0.10 log units) above it; the measured number falls inside the stated range.
By their numbers in this assay, from the lowest: compounds 3, 2 and 1 (each within the scatter of the next).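

Adding a methoxy group on the aromatic carbon that is ortho to a large group and ortho to a methoxy group, which turns 3,4-dimethoxyphenyl into 2,3,4-trimethoxyphenyl, gives a 1.3-fold lower number from compound 2 to compound 3 (0.11 log units; within the scatter) in this assay, so this position accepts a further methoxy group with no change that can be told from the scatter. Within the data shown here, the larger exchange on the saturated ring carbon, from 2-hydroxyphenyl to 2,3,4-trimethoxyphenyl, gives a 1.5-fold lower number from compound 1 to compound 3 (0.16 log units; within the scatter), which shows that even this combined difference does not separate the compounds, a point the single earlier step could not establish for a ring carrying three methoxy groups. No measurement is available that would explain this result.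

The compounds shown leave open whether a group of a different kind on this aromatic carbon, such as an amine or a carboxylic acid, would move the number beyond the scatter. They also leave open whether a longer chain, such as ethoxy or propoxy in place of this methoxy group, would do so.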